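Swapping the aryl on the sulfonyl toward a trifluoromethylphenyl

The source may report more compounds than this note shows. Statements on the series, on what has been measured and on what is new or still open speak of the compounds shown alone.

Of the compounds shown here, three sharing one core have been measured in a functional assay on Umbilical vein for antagonist activity at B1 bradykinin receptor (Homo sapiens), using Schild analysis, with a stated time of 30 min; a higher number here means a more potent compound, by a factor of ten per unit of this negative logarithm, a lower number a less potent compound. Compound 1 `COc1ccc(S(=O)(=O)N(C)CCOCC(=O)N(C)Cc2ccc(C3=NCCN3)cc2)c(C)c1` gives 8.6 in this assay. Compound 2 `CN(Cc1ccc(C2=NCCN2)cc1)C(=O)COCCN(C)S(=O)(=O)c1c(F)cccc1F` gives 7.6. Compound 3 `CN(Cc1ccc(C2=NCCN2)cc1)C(=O)COCCN(C)S(=O)(=O)c1c(Cl)cccc1Cl` gives 8.5, which places it second highest of the three; its nearest neighbour is compound 1, with the step of a number 0.10 log units lower from compound 1 to compound 3 (within the scatter), while the step of a number 0.90 log units higher from compound 2 to compound 3 (beyond the scatter) separates it from compound 2.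

Compound 4 `CN(Cc1ccc(C2=NCCN2)cc1)C(=O)COCCN(C)S(=O)(=O)c1ccccc1C(F)(F)F` has not been measured. It differs from compound 3 in one place: 2-(trifluoromethyl)phenyl in place of 2,6-dichlorophenyl on a sulfonyl sulfur. All three measured steps concern the same aryl group on the sulfonyl sulfur and therefore bear on this change. Two of them, a number 1.00 log units lower from compound 1 to compound 2 (beyond the scatter) and a number 0.90 log units higher from compound 2 to compound 3 (beyond the scatter), show that the aryl group can move the value by a modest amount in either direction, while a number 0.10 log units lower from compound 1 to compound 3 (within the scatter) shows that two quite different aryl groups can also give much the same number.

With no measured aryl bearing a trifluoromethyl to lean on, a modest step in this assay is expected, more likely downward than upward, estimated as a number 0.50 log units lower from compound 3 to compound 4 (beyond the scatter). For compound 4 the expected value is 8, with a range from 7.3 to 8.7.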

Compound 4, negative logarithm of the antagonist equilibrium constant: 9.2
Estimate against measurement, compound 4: 1.20 log units below, outside the stated range (above it).
By their numbers in this assay, from the lowest: compound 2; then compounds 3 and 1 (each within the scatter of the next); then compound 4.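

In this assay, 2-(trifluoromethyl)phenyl on a sulfonyl sulfur gives a higher number than each of the other aryl groups: a number 0.70 log units higher from compound 3 to compound 4 (beyond the scatter), a number 0.60 log units higher from compound 1 to compound 4 (beyond the scatter) and a number 1.60 log units higher from compound 2 to compound 4 (beyond the scatter). The earlier results showed two different aryl groups, in compound 1 and compound 3, giving values within the scatter of each other; compound 4 now shows that this level is not a ceiling for this position, and it is the most potent of the four compounds. Fluorine on the aryl group does not by itself set the number either, since compound 2 and compound 4 both carry it yet mark the two ends of the series, the widest gap among these four compounds.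

Nothing among the data shown accounts for the rise, so its cause remains open. Also open, going by these compounds, is whether the number would hold if the trifluoromethyl were replaced on the same phenyl by a nitrile or a pentafluoroethyl group, and whether the 2-(trifluoromethyl)phenyl gain would persist if the chain joining the sulfonamide nitrogen to the amide were longer.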